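This account rests on a few compounds, and the source may have more. Where it says the series, first, only, none or still open, it means among the compounds named here.

Measured compounds:
compound 1, `CCOC(=O)C[C@H]1[C@@H](O[Si](C)(C)C(C)(C)C)[C@H](n2cnc3c(NC(=O)Nc4ccccc4)ncnc32)O[C@@H]1COC(=O)NC`, 6.52 nM;
compound 2, `CNC(=O)NC[C@H]1O[C@@H](n2cnc3c(NC(=O)Nc4ccccc4)ncnc32)[C@H](O[Si](C)(C)C(C)(C)C)[C@@H]1CC(=O)N(C)OC`, 2.71 nM.

Both compounds share one core and were tested in a functional assay on HOP-92 cells (Homo sapiens) for antiproliferative activity; a higher number here means a weaker inhibitor of growth, a lower number a stronger inhibitor of growth. Compound 2 stands at the lower of the two numbers; compound 1 gives the higher number, and the gap between them is beyond the usual scatter, so compound 2 is the stronger inhibitor of growth of the pair. Compound 3, `CCOC(=O)C[C@H]1[C@@H](O[Si](C)(C)C(C)(C)C)[C@H](n2cnc3c(NC(=O)Nc4ccccc4)ncnc32)O[C@@H]1CNC(=O)NC`, has not yet been measured in this assay. It keeps the methylurea-bearing side of compound 2 and changes the other arm: ethoxy in place of methoxy(methyl)amino on a carbonyl carbon. Among the measured compounds shown here, the ethoxycarbonyl group is the one carried by compound 1, whose value of 6.52 nM is the weaker of the two measured numbers, but no pair of measured compounds differs only in this place, so the step cannot be read off directly. A small loss of potency from compound 2 to compound 3, possibly within the scatter, is expected, amounting to a 1.7-fold higher number from compound 2 to compound 3 (0.22 log units; within the scatter). Compound 3 is estimated to give 4.5 nM, with a range from 1.5 nM to 13 nM.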

Compound 3, concentration for 50% growth inhibition: < 0.01 nM
Compound 3: no number, only a limit; the forecaster's own chance of this, stated with the estimate: 2%; middle value at least 450-fold (2.65 log units) away from the limit.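

In this assay compound 3 gives < 0.01 nM, which is a limit of the assay and not a number: the limit of < 0.01 nM in this assay, at which 1 of the 3 values shown sits. The change on the carbonyl carbon, ethoxy in place of methoxy(methyl)amino, gives an at least 270-fold lower number from compound 2 to compound 3 (2.43 log units; beyond the scatter), and the change on the saturated chain carbon bound to a saturated ring carbon, (methylcarbamoyl)amino in place of (methylcarbamoyl)oxy, gives an at least 650-fold lower number from compound 1 to compound 3 (2.81 log units; beyond the scatter), so each of the two places proves able to carry a large step, which the earlier pair, differing in both places at once, could not show. Compound 1 already carries the ethoxy and compound 2 already carries the (methylcarbamoyl)amino, so the result belongs to the two groups together, a combination that only compound 3 holds.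

Going by these compounds, both steps rest on a limit, so their true size stays open. Also open, on these data alone, is whether this combination tolerates another group on the carbonyl carbon, such as a carboxylic acid, a primary amide or a longer chain like butoxy, and whether the effect reaches beyond this one cell line.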